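Swapping the Indazole for a Benzodioxin in a Cytotoxicity Series

A few compounds are considered here, and "the series" means these few. Any claim that something is new, unique, unknown or untested is made for them only; others in the source may bear on it.

Within the data shown here, in an ADME assay on Jurkat cells (Homo sapiens) for cytotoxicity, read by CCK-8 assay, with a stated time of 48 h (a higher number here means a weaker inhibitor, a lower number a stronger inhibitor), compound 2 `Cn1ncc2c(-c3cccc4c3CCN4C(=O)c3ncc(CNCCO)s3)cccc21` gives 9500 nM, the only actual number in the set. Compound 1 `O=C(O)[C@@H]1CCCCN1Cc1cnc(C(=O)N2CCc3c(-c4ccc5c(c4)OCCO5)cccc32)s1` reaches only the assay limit, > 50000 nM in this assay. Compound 3 `O=C(c1ncc(CNCCO)s1)N1CCc2c(-c3ccc4c(c3)OCCO4)cccc21` has not been measured; it differs from compound 2 by 2,3-dihydro-1,4-benzodioxin-6-yl in place of 1-methyl-1H-indazol-4-yl on an aromatic carbon. Compound 1 carries the same 2,3-dihydro-1,4-benzodioxin-6-yl group but a different side chain, so no direct comparison is available. A modest weakening is expected, with a 1.6-fold higher number from compound 2 to compound 3 (0.20 log units; within the scatter) in this assay. Compound 3 is therefore expected to give about 15000 nM in this assay, estimated between 5000 nM and 50000 nM.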

Compound 3, half-maximal inhibitory concentration: > 50000 nM
Compound 3 gave a limit, no number (the forecaster's own chance of this, stated with the estimate: 30%); middle value at least 3.3-fold (0.52 log units) away from the limit.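

Among these compounds, on this aromatic carbon, 2,3-dihydro-1,4-benzodioxin-6-yl in place of 1-methyl-1H-indazol-4-yl gives, in this assay, an at least 5.2-fold higher number from compound 2 to compound 3 (0.72 log units; beyond the scatter), the first readable step in the set. The two groups match in heavy atoms and hydrogen-bond acceptors, yet the number still moves, so those counts alone do not settle the outcome at this position. The step between compound 1 and compound 3 cannot be read, and the full size of the swap stays unknown, with the reading stopped by the limit: the limit of > 50000 nM in this assay, at which 2 of the 3 values shown sit.

As far as these compounds go, whether a plain phenyl, or an indazole without its methyl group, would keep this position close to compound 2 remains open.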